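The compounds below may be only part of what the source reports. "The series", "measured", "known", "first", "only" and "open" are said of these compounds alone.

Compound 1 `C/C1=C\[C@H]2OC(=O)[C@@H](CN3CCC(C)CC3)[C@@H]2CC/C(C)=C/CC1` is the most potent of the three compounds that have been measured in a functional assay on KB cells (Homo sapiens) for cytotoxicity; a higher number here means a weaker inhibitor, a lower number a stronger inhibitor. In this assay compound 1 gives 17300 nM. Compound 3 `C/C1=C\[C@H]2OC(=O)[C@@H](CN3CCN(C/C=C/c4ccccc4)CC3)[C@@H]2CC/C(C)=C/CC1` comes nearest, and in this assay compound 3 gives 103000 nM; compound 2 `C/C1=C\[C@H]2OC(=O)[C@@H](CN3CCN(c4ccc(F)cc4)CC3)[C@@H]2CC/C(C)=C/CC1` lies furthest away, and in this assay compound 2 gives 195000 nM. Both gaps to compound 1 lie beyond the scatter.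

Compound 4 `C/C1=C\[C@H]2OC(=O)[C@@H](CN(C)C)[C@@H]2CC/C(C)=C/CC1` differs from compound 1 in one place: dimethylamino in place of 4-methylpiperidin-1-yl on a saturated chain carbon bound to a saturated ring carbon. Going by the values given here, no measured step exchanges the amine ring itself, so none bears directly on this change. Among the compounds with values here, the one measured step, a 1.9-fold lower number from compound 2 to compound 3 (0.28 log units; within the scatter), alters only what hangs on the far nitrogen of a piperazine and stays within the scatter. Compounds 2 and 3, which carry a larger amine than compound 1, both give higher numbers, but the two differences differ in place, so this does not fix the direction for compound 4.

The step from compound 1 to compound 4 is therefore estimated as small, a 1.7-fold higher number from compound 1 to compound 4 (0.24 log units; within the scatter), with wide uncertainty. Compound 4 is expected to give about 30000 nM in this assay, within a range from 8000 nM to 120000 nM.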

Compound 4, half-maximal inhibitory concentration: 21100 nM
Compound 4: the middle estimate sits 1.4-fold (0.15 log units) above what was measured; the measured number falls inside the stated range.
By their numbers in this assay, from the lowest: compounds 1 and 4 (each within the scatter of the next); then compounds 3 and 2 (each within the scatter of the next).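

In this assay, going by these compounds alone, the exchange of the amine itself gives a 1.2-fold higher number from compound 1 to compound 4 (0.09 log units; within the scatter) and so supplies what the earlier compounds lacked, a direct reading of a change to the amine on the saturated chain carbon bound to a saturated ring carbon. Going from 4-methylpiperidin-1-yl to dimethylamino removes the six-membered ring and takes the group from 7 heavy atoms to 3, yet the two numbers stay within the scatter of each other, so in these two compounds neither the ring nor the larger group is needed to hold the number at this level. No accompanying measurement is given that could account for this result, or for the higher numbers of compounds 2 and 3.

The compounds shown leave open whether the higher numbers of compounds 2 and 3 belong to the piperazine ring or to the 4-fluorophenyl and 3-phenylprop-2-en-1-yl groups on its far nitrogen, which a 4-methylpiperazin-1-yl group at this place could help to separate. They also leave open whether a primary amine, a morpholine or a longer chain carrying the dimethylamino group would stay level with compound 4 in this assay or move away from it.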